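The compounds below may be only part of what the source reports. "The series", "measured", "known", "first", "only" and "open" are said of these compounds alone.

The measured compounds:
Compound 1, `OC[C@H]1O[C@@H](n2cnc3c(NCc4ccccc4Cl)ncnc32)[C@H](O)[C@@H]1O`, gives > 166000 nM in a functional assay on HOS cells (Homo sapiens) for antiproliferative activity, with a stated time of 72 h (on this read-out higher numbers stand for weaker inhibition and lower numbers for stronger inhibition), which is a limit of the assay and not a number.
Compound 2, `Cc1ccc(CNc2ncnc3c2ncn3[C@@H]2O[C@H](CO)[C@@H](O)[C@H]2O)cc1`, gives > 166000 nM in this assay, again a limit.
Compound 3, `OC[C@H]1O[C@@H](n2cnc3c(NCc4ccc(Cl)cc4Cl)ncnc32)[C@H](O)[C@@H]1O`, gives > 166000 nM in this assay, also a limit.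

Compound 1 therefore stands nowhere in particular among the numbers shown: it sits at the limit, as summarised by the limit of > 166000 nM in this assay, at which 3 of the 3 values shown sit, and no measured compound is separated from it by a readable step.

The unmeasured compound 4, `COc1cccc(CNc2ncnc3c2ncn3[C@@H]2O[C@H](CO)[C@@H](O)[C@H]2O)c1O`, differs from compound 1 in one place: 2-hydroxy-3-methoxyphenyl in place of 2-chlorophenyl on a saturated chain carbon bound to a nitrogen on an aromatic ring. Two measured steps start from compound 1 and change the same group at the same place, so they bear most directly on this change: a step that the two limits leave unreadable from compound 1 to compound 2 and a step that the two limits leave unreadable from compound 1 to compound 3. The remaining step, a step that the two limits leave unreadable from compound 2 to compound 3, is likewise unreadable. None of the three carries a size or a direction, and every value shown is a limit.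

The expectation for compound 4 in this assay is accordingly that it, too, will most likely return only the limit, and the step that the limit leaves unreadable from compound 1 to compound 4 is an estimate rather than a prediction of a readable change. Compound 4 is estimated at 200000 nM, with a range from 40000 nM to 1000000 nM.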

Compound 4, half-maximal inhibitory concentration: > 166000 nM
Compound 4: no number, only a limit; the forecaster's own chance of this, stated with the estimate: 85%; the middle value lies beyond the limit too.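

In this assay compound 4 gives > 166000 nM, which is a limit of the assay and not a number. Its steps from compound 1, compound 2 and compound 3 therefore cannot be read: the limit of > 166000 nM in this assay, at which 4 of the 4 values shown sit. The compounds shown leave open what number any of them would give, and so whether changing this group shifts the read-out at all.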